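Replacing the amide hydrogen: from compound 2 to compound 3

This account rests on a few compounds, and the source may have more. Where it says the series, first, only, none or still open, it means among the compounds named here.

Compound 2 `CCNC(=O)C(=O)CCc1ccc(Cl)cc1` gives 7940 nM in an assay on HEK-293T cells for inhibition of phospholipase A and acyltransferase 3 (Homo sapiens), with stated times of 30 min and 20 min (on this read-out lower numbers stand for stronger inhibition and higher numbers for weaker inhibition), the highest of the two numbers recorded so far. Its nearest neighbour is compound 1 `O=C(CCc1ccc(Cl)cc1)C(=O)NCCCCc1ccccc1`, which gives 1000 nM in this assay. Going by the values given here, the one measured step, a 7.9-fold higher number from compound 1 to compound 2 (0.90 log units; beyond the scatter), comes from removing the phenethyl group on a saturated chain carbon two bonds along the chain from the amide-type nitrogen.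

Compound 3 `O=C(CCc1ccc(Cl)cc1)C(=O)N1CCCCC1` differs from compound 2 in one place: piperidin-1-yl in place of ethylamino on a carbonyl carbon. Among the compounds with values here, no measured step bears directly on this change; the step from compound 1 to compound 2 shows only that adding carbon at the amide side lowered the number. Compound 3 is therefore expected to show a 2.0-fold lower number from compound 2 to compound 3 (0.30 log units; within the scatter), a modest move, uncertain in size. Compound 3 is estimated at 4000 nM, within a range from 1000 nM to 16000 nM.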

Compound 3, half-maximal inhibitory concentration: > 10000 nM
Compound 3: a limit, no number (the forecaster's own chance of this, stated with the estimate: 5%); at least 2.5-fold (0.39 log units) between middle value and limit.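

For compound 3 the read-out in this assay is a limit and not a number: the limit of > 10000 nM in this assay, at which 1 of the 3 values shown sits. Piperidin-1-yl in place of ethylamino on a carbonyl carbon gives an at least 1.2-fold higher number from compound 2 to compound 3 (0.10 log units; that floor lies within the scatter), so this floor does not by itself separate compound 3 from compound 2. Even so, the change adds heavy atoms at the amide side and removes the hydrogen-bond donor without giving a lower number, so compound 3 goes against the earlier reading from compound 1 and compound 2 that added carbon there lowers the number.

From the compounds shown here alone, how far the true value of compound 3 lies from its limit remains open. Also open, going by these compounds, is whether the ring or the loss of the amide hydrogen matters more, which a diethylamino group or a cyclohexylamino group on that carbonyl carbon could help to separate.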